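This account rests on a few compounds, and the source may have more. Where it says the series, first, only, none or still open, it means among the compounds named here.

Compound 3 `CCOC(=O)c1cccc(-c2ccc(C(C)=O)cc2)c1` gives 200000 nM in an assay on COS-7 cells for inhibition of patatin-like phospholipase domain-containing protein 2 (Mus musculus) (on this read-out lower numbers stand for stronger inhibition and higher numbers for weaker inhibition), the highest of the three numbers recorded so far. Compound 1 `CCOC(=O)c1cccc(-c2ccc(OCC)cc2)c1` gives 50000 nM and compound 2 `CCOC(=O)c1cccc(-c2ccc(CN3CCCCC3)cc2)c1` gives 75000 nM; the measured steps are a 4.0-fold higher number from compound 1 to compound 3 (0.60 log units; beyond the scatter) and a 2.7-fold higher number from compound 2 to compound 3 (0.43 log units; beyond the scatter), both modest, whereas a 1.5-fold higher number from compound 1 to compound 2 (0.18 log units; within the scatter). Compound 4 `CCOC(=O)c1cccc(-c2ccc(C(C)N(C)C)cc2)c1` differs from compound 3 in one place: 1-(dimethylamino)ethyl in place of acetyl on an aromatic carbon, the site being para to a large group. The entering group, like the (piperidin-1-yl)methyl of compound 2, carries a nitrogen as its single acceptor and no double bond, so the step that bears on it is a 2.7-fold higher number from compound 2 to compound 3 (0.43 log units; beyond the scatter), here expected to run in reverse. For compound 4 a step of a 2.7-fold lower number from compound 3 to compound 4 (0.43 log units; beyond the scatter) is therefore expected. The estimate for compound 4 is 75000 nM, with a range from 30000 nM to 200000 nM.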

Compound 4, half-maximal inhibitory concentration: 200000 nM
Beside the measured number, compound 4's estimate is 2.7-fold (0.43 log units) below it; measured number inside the range.
By their numbers in this assay, from the lowest: compounds 1 and 2 (each within the scatter of the next); then compounds 3 and 4 (each within the scatter of the next).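

In this assay 1-(dimethylamino)ethyl on this aromatic carbon, para to a large group, gives no change at the digits printed from compound 3 to compound 4 (within the scatter) in place of acetyl, so losing the double bond while keeping one acceptor does not by itself lower the number. The two nitrogen-bearing groups also part, with a 2.7-fold higher number from compound 2 to compound 4 (0.43 log units; beyond the scatter) on exchanging (piperidin-1-yl)methyl, and ethoxy stays ahead, with a 4.0-fold higher number from compound 1 to compound 4 (0.60 log units; beyond the scatter) in the same comparison. Nothing shown gives a cause for these steps.

Open, from the compounds shown here alone, is whether a primary amine or a carboxylic acid on this carbon would move the number, and whether a longer chain ending in piperidine would hold the level of compound 2.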